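The source may report more compounds than this note shows. Statements on the series, on what has been measured and on what is new or still open speak of the compounds shown alone.

The series shares one core, seen in `O=C(NCc1cn(Cc2ccc(Cl)cc2)nn1)c1cn(-c2ccccc2)nc1-c1ccccc1` for compound 1 and `COc1ccc(Cn2cc(CNC(=O)c3cn(-c4ccccc4)nc3-c3ccccc3)nn2)cc1` for compound 2. In a functional assay on MCF7 cells (Homo sapiens) for antiproliferative activity, read by sulforhodamine B assay, with a stated time of 48 h (on this read-out higher numbers stand for weaker inhibition of growth and lower numbers for stronger inhibition of growth), compound 1 gives > 100000 nM, which is a limit of the assay and not a number. In this assay compound 2 gives > 100000 nM, again a limit rather than a measured number. The step that the two limits leave unreadable from compound 1 to compound 2 therefore cannot be read, since both ends sit at the limit of > 100000 nM in this assay, at which 2 of the 2 values shown sit. Compound 2 thus stands at that limit, and the numbers shown do not separate it from compound 1. Compound 3, `COc1ccc(Cn2cc(CNC(=O)c3cn(-c4ccccc4)nc3-c3ccccc3)nn2)cc1OC`, differs from compound 2 by methoxy in place of hydrogen on an aromatic carbon, which read one bond further out is 4-methoxyphenyl to 3,4-dimethoxyphenyl. Within the data shown here, the only measured step, also a change on the 4-methoxybenzyl part, bears on it but carries no readable size. No basis exists for expecting a move beyond the scatter in this assay in either direction. The step from compound 2 to compound 3 is estimated as a step that the limit leaves unreadable from compound 2 to compound 3. Compound 3 is expected to give 150000 nM in this assay, with a range from 30000 nM to 600000 nM, and most likely reported once more only as a limit.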

Compound 3, concentration for 50% growth inhibition: 12600 nM
The estimate for compound 3 lay 12-fold (1.08 log units) above the measured number; measured number outside the range, below it.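

Among these compounds, the 3,4-dimethoxybenzyl compound is the first to give a readable number in this assay, so the benzyl part can affect growth inhibition, which compounds 1 and 2 could not show. Methoxy in place of hydrogen, on the aromatic carbon ortho to a methoxy group and meta to a large group, gives an at least 7.9-fold lower number from compound 2 to compound 3 (0.89 log units; beyond the scatter), and the comparison with the 4-chlorophenyl compound gives an at least 7.9-fold lower number from compound 1 to compound 3 (0.89 log units; beyond the scatter). Both sizes are lower bounds, while the step between compounds 1 and 2 still cannot be read, and the two remain at a limit: the limit of > 100000 nM in this assay, at which 2 of the 3 values shown sit.

Still open, as far as these compounds go, is whether the gain needs both methoxy groups, or whether a lone 3-methoxybenzyl group, a hydroxy group or a longer ethoxy chain at that carbon would read the same way. Also open, from the compounds shown here alone, is whether the number in this assay can move further with a dimethylamino group on the same aromatic ring, or with changes to the two phenyl groups on the shared core.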